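Swapping 2-Hydroxyphenyl for 3-Hydroxyphenyl on a Shared Core

The compounds below may be only part of what the source reports. "The series", "measured", "known", "first", "only" and "open" are said of these compounds alone.

Compound 1 `Oc1ccc(-c2cc(-c3cccc(F)c3)cc(-c3ccccc3O)n2)cc1`: in a functional assay on DU-145 cells (Homo sapiens) for inhibition (on this read-out higher numbers stand for weaker inhibition and lower numbers for stronger inhibition), compound 1 gives only a limit, > 50000 nM.
Compound 2 `Oc1ccc(-c2cc(-c3cccc(F)c3)cc(-c3cccc(O)c3)n2)cc1`: in this assay compound 2 gives 2700 nM.
Compound 3 `Oc1ccccc1-c1cc(-c2ccccc2OC(F)(F)F)cc(-c2ccccc2O)n1`: in this assay compound 3 gives 5850 nM.

The change 3-hydroxyphenyl in place of 2-hydroxyphenyl on an aromatic carbon brought an at least 18-fold lower number from compound 1 to compound 2 (1.26 log units; beyond the scatter); the step is stated as a minimum because compound 1 sits at the limit of > 50000 nM in this assay, at which 1 of the 3 values shown sits. How the core of compound 3 differs from that of compound 1 is not broken down here. Compound 4 `Oc1cccc(-c2cc(-c3ccccc3OC(F)(F)F)cc(-c3ccccc3O)n2)c1` carries the same kind of change, (3-hydroxyphenyl in place of 2-hydroxyphenyl on an aromatic carbon), though the surroundings differ: in the earlier pair the site is meta to a 3-fluorophenyl group and meta to a 4-hydroxyphenyl group, here it is meta to a 2-hydroxyphenyl group and meta to a large group. Resting on the step from compound 1 to compound 2, compound 4 is expected to show a 5.9-fold lower number from compound 3 to compound 4 (0.77 log units; beyond the scatter). Compound 4 is estimated at 1000 nM, between 250 nM and 4000 nM.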

Compound 4, half-maximal inhibitory concentration: > 50000 nM
Compound 4: no number, only a limit (the forecaster's own chance of this, stated with the estimate: 5%); middle value at least 50-fold (1.69 log units) from the limit.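

In this assay the same change gave an at least 8.5-fold higher number from compound 3 to compound 4 (0.93 log units; beyond the scatter), which runs opposite to the earlier pair. Set side by side, the two steps do not agree: the same change on two cores in this assay, an at least 18-fold lower number (1.26 log units; beyond the scatter) from compound 1 to compound 2 and an at least 8.5-fold higher number (0.93 log units; beyond the scatter) from compound 3 to compound 4, at least 150-fold (2.19 log units) apart, beyond the scatter of two such steps

This shows that the effect of 3-hydroxyphenyl in place of 2-hydroxyphenyl did not carry from the core of compound 1 to the core of compound 3, but two pairs cannot show which difference between the cores matters, and both steps are only minimums resting on a limit: the limit of > 50000 nM in this assay, at which 2 of the 4 values shown sit.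

From the compounds shown here alone, it stays open whether the 3-fluorophenyl group, the 4-hydroxyphenyl group or the large group sets the direction of the step. Also open, going by these compounds, is how an aminophenyl group or a carboxylic acid at this site would read in this assay.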